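Removing a Nitro Group on Two Different Cores

This account rests on a few compounds, and the source may have more. Where it says the series, first, only, none or still open, it means among the compounds named here.

Compound 1 `Cc1sc(-c2nsc(=O)o2)cc1[N+](=O)[O-]` gives 53.8% in an ADME assay on L02 cells (Homo sapiens) for inhibition, read by MTT assay, with a stated time of 48 h, tested at 100 uM; on this read-out higher numbers stand for more inhibition at the one concentration tested (going by the name of the read-out) and lower numbers for less inhibition. Compound 2 `Cc1ccc(-c2nsc(=O)o2)s1` differs from compound 1 by hydrogen in place of nitro on an aromatic carbon; in this assay compound 2 gives 25.1%, so the step is a number 28.7 percentage points lower from compound 1 to compound 2 (beyond the scatter). Compound 3 `O=c1oc(-c2ccc([N+](=O)[O-])cc2Cl)ns1`, built on a different core, gives 54.6%; how the two cores differ is not broken down here, and the values of compound 3 and compound 1 lie within the usual scatter of each other. Compound 4 `O=c1oc(-c2ccccc2Cl)ns1` differs from compound 3 by hydrogen in place of nitro on an aromatic carbon, the same kind of change as from compound 1 to compound 2, though here on a six-membered aromatic ring of carbon only, meta to a chloro group, rather than on a five-membered ring with one sulfur next to the methyl-bearing ring atom. For compound 4 the expected step is a number 27.6 percentage points lower from compound 3 to compound 4 (beyond the scatter), resting on a number 28.7 percentage points lower from compound 1 to compound 2 (beyond the scatter). Compound 4 is therefore estimated at 27%, between 12% and 42%.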

Compound 4, a percentage reported as inhibition, at one concentration (the size of the read-out at that concentration, not a potency): 20.6%
Beside the measured number, compound 4's estimate is 6.4 percentage points above it; low and high end bracket the measured number.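

In this assay swapping the nitro group for hydrogen gives a number 34 percentage points lower from compound 3 to compound 4 (beyond the scatter) and so repeats the drop seen on the other core. The change therefore carries over between these two cores, with a step of similar size on each: the same change on two cores in this assay, a number 28.7 percentage points lower (beyond the scatter) from compound 1 to compound 2 and a number 34 percentage points lower (beyond the scatter) from compound 3 to compound 4, 5.3 percentage points apart, within the scatter of two such steps. Among the compounds shown here, this rests on only two pairs of compounds, so it does not show that the same step would appear on any further core, and it does not explain why removing the nitro group lowers the number.

The compounds shown leave open what other groups would do in the place of the nitro group. An amine or a carboxylic acid there might give a number close to that of the nitro compounds, close to that of the hydrogen compounds, or unlike either.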